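A Methyl on the Benzyl Ring of a Weak Inhibitor

A few compounds are considered here, and "the series" means these few. Any claim that something is new, unique, unknown or untested is made for them only; others in the source may bear on it.

Compound 1, `CC(C)(C)c1cc(/C=C/C(=O)NCC2CCN(Cc3ccccc3)CC2)cc(C(C)(C)C)c1O`: 48400 nM
Compound 2, `CC(C)(C)c1cc(/C=C/C(=O)NCCC2CCN(Cc3ccccc3)CC2)cc(C(C)(C)C)c1O`: 62300 nM

Of the compounds shown here, two have so far been tested in an assay on isolated protein for inhibition of Amine oxidase [flavin-containing] A (Homo sapiens), read by fluorescence, with stated times of 15 min and 20 min; a lower number here means a stronger inhibitor, a higher number a weaker inhibitor. Compound 1 gives 48400 nM, and compound 2, which carries one more carbon in the chain between the ring and the amide, gives 62300 nM. Compound 2 has the higher of the two numbers, yet the gap to compound 1 lies within the scatter, so the two cannot be told apart. Both numbers are large, which means that both are weak inhibitors.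

Compound 3, `Cc1ccccc1CN1CCC(CCNC(=O)/C=C/c2cc(C(C)(C)C)c(O)c(C(C)(C)C)c2)CC1`, has not yet been measured. It differs from compound 2 in a single place: methyl in place of hydrogen on an aromatic carbon, so the benzyl group becomes a 2-methylbenzyl group. Among the compounds with values here, no pair of measured compounds shows what a change of this kind does here, so there is no step to lean on. A single added methyl is expected to move the number little in this assay , with no step beyond the scatter in either direction. The estimate for compound 3 is 60000 nM, with a range from 25000 nM to 150000 nM. The expected step is a 1.0-fold lower number from compound 2 to compound 3 (0.02 log units; within the scatter).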

Compound 3, half-maximal inhibitory concentration: 69300 nM
Compound 3: middle estimate off by 1.2-fold (0.06 log units), on the low side; the range from low to high includes it.
By their numbers in this assay, from the lowest: compounds 1, 2 and 3 (each within the scatter of the next).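

In this assay, the change from benzyl to 2-methylbenzyl gives a 1.1-fold higher number from compound 2 to compound 3 (0.05 log units; within the scatter), so the two compounds cannot be told apart. This is the first step shown on the benzyl ring, and it indicates that one methyl on this aromatic carbon, ortho to a large group, brings no gain or loss that can be distinguished from the scatter, so compound 3 remains a weak inhibitor. Nothing measured here explains why the number shows no clear step at this position.

From the compounds shown here alone, a single methyl at one place on the ring says little about what other groups would do there, so it remains open whether a chlorine atom, a methoxy group, an amine or a carboxylic acid at the same carbon would give a step beyond the scatter. Going by these compounds, it also remains open whether the same methyl would give a similar step on compound 1, and whether it would do so on a compound with a longer chain.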